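The source may report more compounds than this note shows. Statements on the series, on what has been measured and on what is new or still open speak of the compounds shown alone.

Measured so far in a functional assay on K562 cells (Homo sapiens) for cytotoxicity, read by MTT assay, with a stated time of 72 h; a higher number here means a weaker inhibitor of growth, a lower number a stronger inhibitor of growth:
- compound 1 `CS/C(=N\C(=O)c1sccc1Cl)NC(=O)c1sccc1Cl`: 78900 nM
- compound 2 `C[Se]/C(=N\C(=O)c1ccco1)NC(=O)c1ccco1`: > 100000 nM

For compound 2 this assay gives only a limit, > 100000 nM, so no number is known for it. It sits at the limit of > 100000 nM in this assay, at which 1 of the 2 values shown sits. Compound 3 `CS/C(=N\C(=O)c1ccco1)NC(=O)c1ccco1` differs from compound 2 by a group of 2 heavy atoms (1 carbon, 1 sulfur; no ring) in place of a group of 2 heavy atoms (1 carbon, 1 selenium; no ring), on a carbon with a double bond to nitrogen, in words: a group of 2 heavy atoms (1 carbon, 1 sulfur; no ring) in place of a group of 2 heavy atoms (1 carbon, 1 selenium; no ring), on a carbon with a double bond to nitrogen. Compound 1 carries the same methylsulfanyl group on a different core and gives 78900 nM. Going by the values given here, no measured step covers this exchange; the expected step from compound 2 to compound 3 is a number no higher from compound 2 to compound 3 (the limit leaves the size open), not beyond the scatter. Compound 3 is estimated at 100000 nM, range 40000 nM to 250000 nM, and may again return only a limit.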

Compound 3, concentration for total growth inhibition: > 100000 nM
Compound 3 gave a limit, no number; the forecaster's own chance of this, stated with the estimate: 55%; the middle value sits exactly at the limit.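

Compound 2 and compound 3 each return only a limit, so no step can be read for the exchange to methylsulfanyl: the limit of > 100000 nM in this assay, at which 2 of the 3 values shown sit.

The compounds shown leave open whether this exchange changes growth inhibition at all, and by how much.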